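A few compounds are considered here, and "the series" means these few. Any claim that something is new, unique, unknown or untested is made for them only; others in the source may bear on it.

Three compounds have a reading so far in a physicochemical assay for lipophilicity; a higher number here means a more lipophilic compound, a lower number a more polar compound. Compound 1 `Cc1cccc2c1OP(=O)(OCC1CCC(n3cnc4c(O)ncnc43)O1)OC2` gives 0.14 and compound 2 `Nc1ncnc2c1ncn2[C@H]1C=C[C@@H](COP2(=O)OCc3ccccc3O2)O1` gives 0.36, while compound 3 `Cc1cc(C)c2c(c1)COP(=O)(OC[C@@H]1C=C[C@H](n3cnc4c(N)ncnc43)O1)O2` gives 0.95 (the highest of the three, and beyond the scatter from each of the other two).

Compound 4 `Cc1cccc2c1OP(=O)(OC[C@@H]1C=C[C@H](n3cnc4c(N)ncnc43)O1)OC2` has not yet been measured. It differs from compound 3 in one place: hydrogen in place of methyl on an aromatic carbon. For the measured compounds named here, no pair of measured compounds in this small set shows that change on its own, so there is no direct precedent for its size. In this assay a fall rather than a rise is expected, of moderate size, close to the edge of the scatter or a little beyond it. Compound 4 is expected to remain within the span set by compound 2 0.36 and compound 3 0.95, and not to reach the low reading of compound 1 0.14. The expected change a number 0.30 log units lower from compound 3 to compound 4 (within the scatter) is thus a modest decrease. For compound 4 the estimated value is 0.65, with an expected range from 0.35 to 0.95 when it is measured.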

Compound 4, partition coefficient: 0.63
Compound 4: the middle estimate sits 0.02 log units above what was measured, within the range that was stated.
By their numbers in this assay, from the lowest: compounds 1, 2 and 4 (each within the scatter of the next, the first and the last beyond it); then compound 3.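

In this assay, taking away this one methyl, which leaves a hydrogen on an aromatic carbon meta to a fused ring and para to a fused ring, gives a number 0.32 log units lower from compound 3 to compound 4 (beyond the scatter), so a single heavy atom at this position is enough to move the reading just past the usual scatter. For the compounds shown here, the step is modest, however, and it is the only view of this position in the set, since no earlier pair isolated a change in one place. The methyl that compound 4 keeps, on a different aromatic carbon, is a smaller matter in the reading: adding it to the bare ring gives a number 0.27 log units higher from compound 2 to compound 4 (within the scatter), so in these two steps only the methyl lost from compound 3 clears the scatter. Nothing shown accounts for the size of either step. Going by these compounds, it remains open how this position would respond to a group other than methyl, such as chlorine, methoxy or a longer chain like ethyl, and whether the step from hydrogen to methyl would be the same size on a core without the second methyl.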